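The compounds below may be only part of what the source reports. "The series", "measured", "known", "first", "only" and "open" are said of these compounds alone.

Measured so far:
- compound 1 `CC(C)(C)Sc1c(CC(C)(C)C(=O)O)n(Cc2ccc(Cl)cc2)c2ccc(OCc3ccc4cc(F)ccc4n3)cc12`: 2 nM
- compound 2 `CC(C)(C)Sc1c(CC(C)(C)C(=O)O)n(Cc2ccc(Cl)cc2)c2ccc(OCc3ccc4cccnc4n3)cc12`: 6 nM
- compound 3 `COc1ccc2nc(COc3ccc4c(c3)c(SC(C)(C)C)c(CC(C)(C)C(=O)O)n4Cc3ccc(Cl)cc3)sc2c1`: 8 nM

These values come from a functional assay for inhibition, with Homo sapiens as the target; on this read-out higher numbers stand for weaker inhibition and lower numbers for stronger inhibition. The upper, weaker end of this small set is shared: a 1.3-fold higher number from compound 2 to compound 3 (0.12 log units; within the scatter) lies within the scatter, whereas a 4.0-fold higher number from compound 1 to compound 3 (0.60 log units; beyond the scatter) lies beyond it.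

Compound 4 `Cc1nc2ccc(COc3ccc4c(c3)c(SC(C)(C)C)c(CC(C)(C)C(=O)O)n4Cc3ccc(Cl)cc3)cc2s1` differs from compound 3 in one group: 2-methyl-1,3-benzothiazol-6-yl in place of 6-methoxy-1,3-benzothiazol-2-yl on a saturated chain carbon bound to an oxygen on an aromatic ring. In words, this is 2-methyl-1,3-benzothiazol-6-yl in place of 6-methoxy-1,3-benzothiazol-2-yl. Within the data shown here, the other swaps at this place gave modest steps at most, such as a 3.0-fold higher number from compound 1 to compound 2 (0.48 log units; beyond the scatter), although no measured pair shows this exact change. No step beyond the scatter is therefore expected, and the estimated step is a 1.3-fold higher number from compound 3 to compound 4 (0.10 log units; within the scatter). For compound 4 the estimated value is 10 nM, with an expected range of 3 nM to 30 nM.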

Compound 4, half-maximal inhibitory concentration: 6 nM
Estimate against measurement, compound 4: 1.7-fold (0.22 log units) above, and the stated range covers the measured number.
By their numbers in this assay, from the lowest: compound 1; then compounds 2, 4 and 3 (each within the scatter of the next).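

Swapping 6-methoxy-1,3-benzothiazol-2-yl for 2-methyl-1,3-benzothiazol-6-yl leaves the number essentially unchanged, with a 1.3-fold lower number from compound 3 to compound 4 (0.12 log units; within the scatter), and the same holds against the two-nitrogen group of compound 2, with no change at the digits printed from compound 2 to compound 4 (within the scatter). Only the 6-fluoroquinolin-2-yl group stands apart, with a 3.0-fold higher number from compound 1 to compound 4 (0.48 log units; beyond the scatter). No measurement offers an explanation for these steps. As far as these compounds go, the swap changes both the attached group and the ring's point of attachment, and the share of each stays open. Also open, from the compounds shown here alone, is how an amine or a carboxylic acid on this benzothiazole would fare.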